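The source may report more compounds than this note shows. Statements on the series, on what has been measured and on what is new or still open speak of the compounds shown alone.

Values so far in a functional assay on A549 cells (Homo sapiens) for inhibition, read by MTT assay, with a stated time of 72 h; a lower number here means a stronger inhibitor, a higher number a weaker inhibitor
- compound 1 `COc1cc2c(Oc3ccc(NC(=O)c4nn(-c5ccccc5C)cc(C)c4=O)cc3)ccnc2cc1OCCCC(=O)NO` gives 4460 nM
- compound 2 `COc1cc2c(Oc3ccc(NC(=O)c4nn(-c5ccccc5C)ccc4=O)cc3F)ccnc2cc1OCCCC(=O)NO` gives 5740 nM
- compound 3 `COc1cc2c(Oc3ccc(NC(=O)c4nn(-c5ccccc5F)cc(C)c4=O)cc3F)ccnc2cc1OCCCC(=O)NO` gives 1370 nM

Compound 3 has the lowest of the three numbers, and its gaps to compound 1 and to compound 2 both lie beyond the scatter. Compound 4 `COc1cc2c(Oc3ccc(NC(=O)c4nn(-c5ccccc5C)cc(C)c4=O)cc3F)ccnc2cc1OCCCC(=O)NO`, not yet measured, carries methyl in place of fluoro on an aromatic carbon, which reads as 2-fluorophenyl to 2-methylphenyl. For the measured compounds named here, no measured pair isolates this change. Compound 1 at 4460 nM and compound 2 at 5740 nM both carry the 2-methylphenyl group, but each also differs from compound 4 elsewhere, so they serve only as a loose guide. In this assay a weaker result is expected, with a step near the edge of the scatter. The expected change is a 2.0-fold higher number from compound 3 to compound 4 (0.31 log units; beyond the scatter) in the number. For compound 4 the estimated value is 2800 nM, with an expected range of 1300 nM to 6000 nM.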

Compound 4, half-maximal inhibitory concentration: 2090 nM
Compound 4: the middle estimate sits 1.3-fold (0.13 log units) above what was measured; measured number inside the range.
By their numbers in this assay, from the lowest: compounds 3 and 4 (each within the scatter of the next); then compounds 1 and 2 (each within the scatter of the next).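

In this assay, going from 2-fluorophenyl to 2-methylphenyl (a 1.5-fold higher number from compound 3 to compound 4 (0.18 log units; within the scatter)) leaves no readable difference, so either group can occupy this position without a clear shift in the number. The two other single changes do register as modest steps: the gain of a methyl group (a 2.7-fold lower number from compound 2 to compound 4 (0.44 log units; beyond the scatter)) and fluoro in place of hydrogen on an aromatic carbon (a 2.1-fold lower number from compound 1 to compound 4 (0.33 log units; beyond the scatter)). Among these three steps, only the exchange of fluoro and methyl stays within the scatter, though three steps set no general rule for the series.

No supporting measurement accounts for any of these steps. Open too, from the compounds shown here alone, is how a chloro group, an amine or a longer chain on this aromatic carbon would compare with fluoro and methyl in the same cell read-out.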